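The source may report more compounds than this note shows. Statements on the series, on what has been measured and on what is new or still open speak of the compounds shown alone.

The series shares one core, each member carrying a different aryl group on it. Compound 1 `O=C1CSC(c2c(Cl)cccc2Cl)N1CCN1CCCCC1` gives 75% in an ADME assay on Vero cells (Chlorocebus sabaeus) for cytotoxicity, read by neutral red uptake, tested at 197 ug/mL; on this read-out higher numbers stand for a weaker effect at the one concentration tested and lower numbers for a stronger effect. Compound 2 `O=C1CSC(c2ccc([N+](=O)[O-])cc2)N1CCN1CCCCC1` gives 72%, and compound 3 `COc1ccccc1C1SCC(=O)N1CCN1CCCCC1` gives 72%. Compound 2 thus sits level with compound 3 at the digits reported, and its gap to compound 1 lies within the usual scatter, so the three numbers cannot be told apart. Compound 4 `O=C1CSC(c2ccc(Cl)cc2)N1CCN1CCCCC1` has not yet been measured; it differs from compound 2 by chloro in place of nitro on an aromatic carbon. Among the measured compounds shown here, no pair of measured compounds differing in one place exists here to show the size of such a step. Because compound 1 gives 75% and compound 3 gives 72% with other aryl groups, all within the scatter of one another, compound 4 is expected to show a number 1 percentage points higher from compound 2 to compound 4 (within the scatter), no step beyond the scatter. Compound 4 is therefore estimated at 73%, within 60% to 85%.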

Compound 4, a percentage reported as activity, at one concentration (the size of the read-out at that concentration, not a potency): 68%
Compound 4: middle estimate off by 5 percentage points, on the high side, and the stated range covers the measured number.
By their numbers in this assay, from the lowest: compounds 4, 2, 3 and 1 (each within the scatter of the next).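

In this assay, among the compounds shown here, this is the first comparison in which only the group on this aromatic carbon, para to a large group, changes. Chloro in place of nitro gives a number 4 percentage points lower from compound 2 to compound 4 (within the scatter) and so leaves the two compounds inseparable, even though a single chlorine replaces a nitro group of three heavy atoms. Nothing measured here bears on the reason for this result. Going by these compounds, whether an amine or a carboxylic acid on this same carbon would give a step beyond the scatter remains open. So does what a plain hydrogen there would give.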